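A few compounds are considered here, and "the series" means these few. Any claim that something is new, unique, unknown or untested is made for them only; others in the source may bear on it.

Measured compounds:
compound 1 `CN1CCN(CCCCCCn2c3c(c4ccccc42)C(=O)c2c[n+]([O-])c4ccccc4c2C3=O)CC1` — 330 nM
compound 2 `O=C1c2c[n+]([O-])c3ccccc3c2C(=O)c2[nH]c3ccccc3c21` — 320 nM
compound 3 `CCCN1CCN(CCCCn2c3c(c4ccccc42)C(=O)c2c[n+]([O-])c4ccccc4c2C3=O)CC1` — 320 nM

In a functional assay on A549 cells (Homo sapiens) for cytotoxicity, read by MTT assay, with a stated time of 72 h (a higher number here means a weaker inhibitor, a lower number a stronger inhibitor), compound 3 gives 320 nM, level with compound 2 at the digits shown; together these two are the lowest of the three numbers, and compound 1 sits so close that no order can be read among them. For the measured compounds named here, the one single-point step available, a 1.0-fold lower number from compound 1 to compound 3 (0.01 log units; within the scatter), lies within the scatter: swapping one piperazine end-group for another on the chain left the number where it was. Compound 2, which carries no chain on the aromatic nitrogen at all, gives a number indistinguishable from compound 3, so across these three compounds the tail has not moved the read-out.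

Compound 4 `O=C1c2c[n+]([O-])c3ccccc3c2C(=O)c2c1c1ccccc1n2CCCCn1ccnc1` is the next point: 1H-imidazol-1-yl in place of 4-propylpiperazin-1-yl on a saturated chain carbon, four bonds along the chain from an aromatic nitrogen. Going by the values given here, no measured step replaces a piperazine end-group with an imidazole, so the change is untested here; what the three numbers show is that neither varying nor removing the tail has shifted the result beyond the scatter. On that basis no step beyond the scatter is expected, and the estimate for compound 4 is 320 nM (range 150 nM to 700 nM), corresponding to an expected step of no change at the digits printed from compound 3 to compound 4 (within the scatter).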

Compound 4, half-maximal inhibitory concentration: 170 nM
Compound 4: middle estimate off by 1.9-fold (0.27 log units), on the high side, and the stated range covers the measured number.
By their numbers in this assay, from the lowest: compounds 4, 2, 3 and 1 (each within the scatter of the next).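

In this assay, the 1H-imidazol-1-yl end-group gives a 1.9-fold lower number from compound 3 to compound 4 (0.27 log units; within the scatter) and a 1.9-fold lower number from compound 1 to compound 4 (0.29 log units; within the scatter), so at this place, on a saturated chain carbon four bonds along the chain from an aromatic nitrogen, a five-membered aromatic ring stands level with the six-membered non-aromatic rings of the piperazine tails within the scatter. The whole 4-(1H-imidazol-1-yl)butyl group in place of hydrogen on the aromatic nitrogen gives a 1.9-fold lower number from compound 2 to compound 4 (0.27 log units; within the scatter), so the imidazole-bearing chain, like the piperazine-bearing chains before it, cannot be told apart from the bare core. All three steps lie within the scatter and share one compound, so they support no order among the four compounds, and no measurement is at hand that would account for the level of any of them.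

Still open, as far as these compounds go, is whether a terminal dimethylamino group or a carboxylic acid at the end of the same chain would stay at this level. Also open, from the compounds shown here alone, is whether 1H-imidazol-1-yl on a propyl chain or on a longer chain such as octyl would hold it.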